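This account rests on a few compounds, and the source may have more. Where it says the series, first, only, none or still open, it means among the compounds named here.

Of the compounds shown here, three share one core and have been tested in a functional assay on HT-29 cells (Homo sapiens) for cytotoxicity, read by MTT assay, with a stated time of 72 h; on this read-out lower numbers stand for stronger inhibition and higher numbers for weaker inhibition. Compound 1 `O=C(Nc1nc2ccccc2s1)c1cn(-c2ccccc2)nc1-c1ccccc1` gives 16800 nM. Compound 2 `O=C(Nc1nc2ccccc2s1)c1cn(-c2ccccc2)nc1-c1ccc(F)cc1` gives 9060 nM, the low end of the three numbers, though its gap to compound 1 lies within the scatter. Compound 3 `COc1ccc2nc(NC(=O)c3cn(-c4ccccc4)nc3-c3ccc(F)cc3)sc2c1` gives 33200 nM. Compound 4 `COc1ccc(-c2nn(-c3ccccc3)cc2C(=O)Nc2nc3ccccc3s2)cc1` is not yet measured; relative to compound 2 it carries methoxy in place of fluoro on an aromatic carbon. Among the measured compounds shown here, no measured step swaps these two groups directly. Adding fluoro brought a 1.9-fold lower number from compound 1 to compound 2 (0.27 log units; within the scatter), while adding methoxy at a different place brought a 3.7-fold higher number from compound 2 to compound 3 (0.56 log units; beyond the scatter). A small rise, near the edge of the scatter, is therefore expected: a 1.5-fold higher number from compound 2 to compound 4 (0.19 log units; within the scatter). Compound 4 is expected to give 14000 nM, within a range from 6000 nM to 35000 nM.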

Compound 4, half-maximal inhibitory concentration: 10500 nM
Compound 4: middle estimate off by 1.3-fold (0.12 log units), on the high side; the measured number falls inside the stated range.
By their numbers in this assay, from the lowest: compounds 2, 4, 1 and 3 (each within the scatter of the next, the first and the last beyond it).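

At this position, para to a large group, methoxy and fluoro cannot be told apart (a 1.2-fold higher number from compound 2 to compound 4 (0.06 log units; within the scatter)). Methoxy in place of hydrogen here also stays within the scatter (a 1.6-fold lower number from compound 1 to compound 4 (0.20 log units; within the scatter)). The rise seen with compound 3 therefore does not carry over to this position, and the same change reads differently at the two places: the same change on two cores in this assay, a 3.7-fold higher number (0.56 log units; beyond the scatter) from compound 2 to compound 3 and a 1.6-fold lower number (0.20 log units; within the scatter) from compound 1 to compound 4, 5.9-fold (0.77 log units) apart, beyond the scatter of two such steps.

As far as these compounds go, whether an amine, a carboxylic acid or a longer chain at this position would move the number beyond the scatter remains open. Also open, from the compounds shown here alone, is whether the rise with compound 3 depends on the fluoro it carries.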